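Shrinking one ring on compound 2

This account rests on a few compounds, and the source may have more. Where it says the series, first, only, none or still open, it means among the compounds named here.

In a functional assay (trachea) for inhibition, with Cavia porcellus as the target (on this read-out lower numbers stand for stronger inhibition and higher numbers for weaker inhibition), compound 1 `CCc1ccc2c(c1)C(C)(C)[C@@H](O)[C@@H]2N1CCCCC1=O` is reported only as > 20000 nM here, and that figure is a limit of the assay rather than a number. Compound 2 `CC1(C)C=C(N2CCCCC2=O)c2cc([N+](=O)[O-])ccc21` gives 2240 nM in the same assay. For the measured compounds named here, this is the only actual number so far, which makes compound 2 the sole firm reference point.

The next compound to be tested is compound 3 `C[C@@H]1CCC(=O)N1C1=CC(C)(C)c2ccc([N+](=O)[O-])cc21`. It keeps the shared core of compound 2 but changes the group on a double-bonded ring carbon, where a five-membered non-aromatic ring replaces a six-membered one and a defined stereocentre appears: a group of 7 heavy atoms (5 carbon, 1 nitrogen, 1 oxygen; one five-membered non-aromatic ring with 1 hetero atom) in place of a group of 7 heavy atoms (5 carbon, 1 nitrogen, 1 oxygen; one six-membered non-aromatic ring with 1 hetero atom), on a double-bonded ring carbon.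

Going by the values given here, no measured pair shows what such an exchange does. The expectation therefore leans on compound 2 at 2240 nM as its starting point, since the two groups match in their counted atoms. Little change is expected, with an estimated 1.1-fold lower number from compound 2 to compound 3 (0.05 log units; within the scatter) that stays within the usual scatter, in neither direction clearly. For compound 3 the estimated value is 2000 nM in this assay, with an expected range from 400 nM to 10000 nM around it.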

Compound 3, half-maximal inhibitory concentration: 2420 nM
Beside the measured number, compound 3's estimate is 1.2-fold (0.08 log units) below it; low and high end bracket the measured number.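

Swapping the 2-oxopiperidin-1-yl group for the five-membered ring on this double-bonded ring carbon gives, in this assay, a 1.1-fold higher number from compound 2 to compound 3 (0.03 log units; within the scatter), so the two compounds cannot be told apart on this read-out. For the compounds shown here, this is the first measured pair that changes this position, and it shows that ring size and a new defined stereocentre can change together here with no readable shift in the number, while the counted heavy atoms and the single hydrogen-bond acceptor stay the same. Compound 1 gives no number to set against this pair, and its entry is a limit of the assay: the limit of > 20000 nM in this assay, at which 1 of the 3 values shown sits.

Because ring size and the stereocentre change in the same step, the compounds shown cannot separate what each does on its own, and a pair in which only one of them differs would be needed to say more. On these data alone, it also stays open whether a group of a different kind on this carbon, such as a piperidine ring without the carbonyl, a carboxylic acid or a longer open chain, would move the number beyond the scatter.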